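This account rests on a few compounds, and the source may have more. Where it says the series, first, only, none or still open, it means among the compounds named here.

Of the compounds shown here, three sharing one core have been tested in a functional assay on CHO cells for agonist activity at adenosine receptor A1 (Homo sapiens), read by fluorescence and ERK phosphorylation, with stated times of 30 min and 1.5 h, tested at 10 uM; on this read-out lower numbers stand for a weaker effect and higher numbers for a stronger effect at the one concentration tested. Compound 1 `Nc1scc(-c2cccc(C(F)(F)F)c2)c1C(=O)c1ccccc1` gives 59%. Compound 2 `Nc1scc(-c2ccccc2)c1C(=O)c1ccccc1`, which carries hydrogen in place of trifluoromethyl on an aromatic carbon, gives 48%, so that a number 11 percentage points lower from compound 1 to compound 2 (beyond the scatter). Compound 3 `Nc1scc(-c2cccc(C(F)(F)F)c2)c1C(=O)c1ccc(Cl)cc1`, which carries chloro in place of hydrogen on an aromatic carbon, gives 73%, so that a number 14 percentage points higher from compound 1 to compound 3 (beyond the scatter). Compound 3 thus stands highest of the three numbers, with compound 1 nearest and compound 2 furthest, both gaps lying beyond the scatter.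

Compound 4 `Nc1scc(-c2ccccc2)c1C(=O)c1ccc(Cl)cc1` has not yet been measured in this assay. It differs from compound 3 in one place: hydrogen in place of trifluoromethyl on an aromatic carbon. The same change has been seen once before, in the step of a number 11 percentage points lower from compound 1 to compound 2 (beyond the scatter), a modest fall beyond the scatter. A fall of similar size is therefore expected here, namely a number 11 percentage points lower from compound 3 to compound 4 (beyond the scatter). For compound 4 the estimate in this assay is 62%, with a range from 48% to 76%.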

Compound 4, a percentage reported as activity, at one concentration (the size of the read-out at that concentration, not a potency): 64%
The estimate for compound 4 lay 2 percentage points below the measured number, and the stated range covers the measured number.
By their numbers in this assay, from the lowest: compound 2; then compounds 1, 4 and 3 (each within the scatter of the next, the first and the last beyond it).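

In this assay, taking trifluoromethyl off the aromatic ring now has a second reading, on the core that carries the chloro group, giving a number 9 percentage points lower from compound 3 to compound 4 (within the scatter), and this agrees with the first reading: the same change on two cores in this assay, a number 11 percentage points lower (beyond the scatter) from compound 1 to compound 2 and a number 9 percentage points lower (within the scatter) from compound 3 to compound 4, 2 percentage points apart, within the scatter of two such steps The chloro group also has a second reading, on the core without trifluoromethyl, giving a number 16 percentage points higher from compound 2 to compound 4 (beyond the scatter), and this agrees with its first reading as well: the same change on two cores in this assay, a number 14 percentage points higher (beyond the scatter) from compound 1 to compound 3 and a number 16 percentage points higher (beyond the scatter) from compound 2 to compound 4, 2 percentage points apart, within the scatter of two such steps Across these four compounds, each change therefore shifts the number by a similar amount whether or not the other group is present, something the first three compounds could not show.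

From the compounds shown here alone, it remains open whether this holds for other groups, such as a nitrile or a methoxy group in place of trifluoromethyl, or a fluoro group or an amine in place of chloro. A reading at a single concentration also speaks, for all four compounds, only of a stronger or weaker effect at that concentration.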